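The compounds below may be only part of what the source reports. "The series", "measured", "known", "first", "only" and "open" are said of these compounds alone.

Three compounds share one core and differ only in the group carried on the ring attached to an amine nitrogen in a ring. Compound 1 `COc1ccccc1N1CCN(CCCNc2ncccc2C(=O)N(C)C)CC1` carries a methoxy group, and in a functional assay for antagonist activity at Alpha-1A adrenergic receptor (Oryctolagus cuniculus) (a lower number here means tighter binding, a higher number weaker binding), compound 1 gives 1.59 nM. Compound 2 `CN(C)C(=O)c1cccnc1NCCCN1CCN(c2ccccc2C2CC2)CC1` carries a cyclopropyl group instead, and in this assay compound 2 gives 0.631 nM, which is a 2.5-fold lower number from compound 1 to compound 2 (0.40 log units; beyond the scatter). Compound 3 `CN(C)C(=O)c1cccnc1NCCCN1CCN(c2ccccc2C(F)(F)F)CC1` carries a trifluoromethyl group, and in this assay compound 3 gives 12.6 nM, the highest number of the three: a 7.9-fold higher number from compound 1 to compound 3 (0.90 log units; beyond the scatter), and a 20-fold higher number from compound 2 to compound 3 (1.30 log units; beyond the scatter).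

Compound 4 `COc1cc(C)ccc1N1CCN(CCCNc2ncccc2C(=O)N(C)C)CC1` has not yet been measured. The change from compound 3 is 2-methoxy-4-methylphenyl in place of 2-(trifluoromethyl)phenyl on an amine nitrogen in a ring. For the measured compounds named here, the measured step that bears on it is the one from compound 1 to compound 3, which runs the other way and was modest; no measured step covers the added methyl group, so its effect is unknown. A modest step toward a lower number is therefore expected, landing near compound 1. Compound 4 is expected to give about 1.6 nM in this assay, within a range from 0.5 nM to 5 nM, which would be an expected step of a 7.9-fold lower number from compound 3 to compound 4 (0.90 log units; beyond the scatter).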

Compound 4, dissociation constant: 0.794 nM
For compound 4 the middle estimate is 2.0-fold (0.30 log units) above the measured one, and the stated range covers the measured number.
By their numbers in this assay, from the lowest: compounds 2, 4 and 1 (each within the scatter of the next, the first and the last beyond it); then compound 3.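

For the compounds shown here, compound 4 is the first in this set whose ring carries a second group, and the added methyl can be read directly: a 2.0-fold lower number from compound 1 to compound 4 (0.30 log units; within the scatter) in this assay. So in this assay, that methyl group on an aromatic carbon can be present without moving the number beyond the usual scatter. The large step back from trifluoromethyl (a 16-fold lower number from compound 3 to compound 4 (1.20 log units; beyond the scatter)) and the comparison with the cyclopropyl compound (a 1.3-fold higher number from compound 2 to compound 4 (0.10 log units; within the scatter)) place 2-methoxy-4-methylphenyl with the two better groups, well apart from 2-(trifluoromethyl)phenyl. No supporting measurement explains these steps.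

The compounds shown leave open whether the methyl group would behave the same way alongside cyclopropyl or trifluoromethyl. They also leave open how a chlorine atom or a nitrile group would fare in place of methoxy.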